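Swapping Fluoro for Methoxy in a Cytotoxicity Series

The source may report more compounds than this note shows. Statements on the series, on what has been measured and on what is new or still open speak of the compounds shown alone.

Two measured compounds share one core and differ only in where a fluoro group sits on an aromatic ring. In a functional assay on Huh-7 cells (Homo sapiens) for cytotoxicity, with a stated time of 48 h (a higher number here means a weaker inhibitor, a lower number a stronger inhibitor), compound 1 `O=[N+]([O-])c1ccc(CN2CCC(n3cc(CC(OCc4cc(-c5ccc(F)cc5)no4)c4ccc(Br)cc4)nn3)CC2)cc1` gives 2000 nM. Compound 2 `O=[N+]([O-])c1ccc(CN2CCC(n3cc(CC(OCc4cc(-c5cccc(F)c5)no4)c4ccc(Br)cc4)nn3)CC2)cc1` gives 3000 nM in this assay, the higher of the two numbers, yet the step of a 1.5-fold higher number from compound 1 to compound 2 (0.18 log units; within the scatter) falls within the scatter, so the pair cannot truly be told apart. Compound 3 `COc1cccc(-c2cc(COC(Cc3cn(C4CCN(Cc5ccc([N+](=O)[O-])cc5)CC4)nn3)c3ccc(Br)cc3)on2)c1` has not been measured; its change from compound 2 is methoxy in place of fluoro on an aromatic carbon. Within the data shown here, no measured step tests such an exchange of one group for another, and the sole step in hand, a shift of the fluoro group, changed the number by less than the scatter. The step of a 1.2-fold higher number from compound 2 to compound 3 (0.07 log units; within the scatter) is therefore expected to be no larger than the scatter. The estimate for compound 3 is 3500 nM, with a range from 1500 nM to 8000 nM.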

Compound 3, half-maximal inhibitory concentration: 5000 nM
Estimate against measurement, compound 3: 1.4-fold (0.15 log units) below; the measured number falls inside the stated range.
By their numbers in this assay, from the lowest: compounds 1, 2 and 3 (each within the scatter of the next, the first and the last beyond it).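

In this assay, among these compounds, methoxy in place of fluoro on this aromatic carbon gives a 1.7-fold higher number from compound 2 to compound 3 (0.22 log units; within the scatter), so the first exchange of one group for another at this position, like the earlier shift of fluoro, cannot be told apart from repeat-measurement noise. Setting 3-methoxyphenyl against 4-fluorophenyl gives a 2.5-fold higher number from compound 1 to compound 3 (0.40 log units; beyond the scatter), the only step in the series to clear the scatter, though it is modest and changes both the group and its place on the ring at once. No supporting data are available to explain this step.

A compound carrying methoxy where compound 1 carries fluoro would separate the effect of the group from that of its place. On these data alone, how an amine or a carboxylic acid on this ring would read in this assay remains open.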